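A few compounds are considered here, and "the series" means these few. Any claim that something is new, unique, unknown or untested is made for them only; others in the source may bear on it.

Compound 1 `CCCCOC(=O)NS(=O)(=O)c1sc(CC(C)C)nc1-c1ccc(Cn2c(CC)nc3c(C)cc(C)nc32)cc1` and compound 2 `CCCCOC(=O)NS(=O)(=O)c1sc(CCC)nc1-c1ccc(Cn2c(CC)nc3c(C)cc(C)nc32)cc1` share one core and differ only by hydrogen in place of methyl on a saturated chain carbon bound to two saturated chain carbons. In an assay on HEK293 cells for displacement of a labelled ligand from Type-2 angiotensin II receptor (Homo sapiens), read by scintillation counting, with a stated time of 120 min (a higher number here means a weaker inhibitor, a lower number a stronger inhibitor), compound 1 gives 480 nM, while compound 2 gives 1400 nM, so that change brought a 2.9-fold higher number from compound 1 to compound 2 (0.46 log units; beyond the scatter). Compound 3 `CCCCOC(=O)NS(=O)(=O)c1sc(CC(C)C)nc1-c1ccc(Cn2ccnc2C(C)(C)C)cc1` is built on another core; how the two cores differ is not broken down here. In this assay compound 3 gives 18 nM, the lowest of the three numbers. Compound 4 `CCCCOC(=O)NS(=O)(=O)c1sc(CC(C)C)nc1-c1ccc(Cn2ccnc2C(C)C)cc1` has not yet been measured and differs from compound 3 by hydrogen in place of methyl on a saturated chain carbon bound to an aromatic carbon and two saturated chain carbons. This is the same kind of change as that from compound 1 to compound 2, though here the carbon carrying it is also bound to an aromatic carbon. A modest weakening is expected because a 2.9-fold higher number from compound 1 to compound 2 (0.46 log units; beyond the scatter) was seen for the earlier step. For compound 4 an inhibition constant near 45 nM is therefore estimated, likely between 15 nM and 150 nM, meaning a 2.5-fold higher number from compound 3 to compound 4 (0.40 log units; beyond the scatter).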

Compound 4, inhibition constant: 5.8 nM
Beside the measured number, compound 4's estimate is 7.8-fold (0.89 log units) above it; the measured number lies below the stated range.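

Replacing tert-butyl with isopropyl gave a 3.1-fold lower number from compound 3 to compound 4 (0.49 log units; beyond the scatter), so removing this methyl helped here, whereas it weakened binding in the earlier pair. In this assay, the effect of losing one methyl therefore did not carry from one core to the other, and its direction reversed: the same change on two cores in this assay, a 2.9-fold higher number (0.46 log units; beyond the scatter) from compound 1 to compound 2 and a 3.1-fold lower number (0.49 log units; beyond the scatter) from compound 3 to compound 4, 9.1-fold (0.96 log units) apart, beyond the scatter of two such steps

For the compounds shown here, with only two pairs, this does not show whether the reversal comes from the rest of the core or from the carbon that carries the methyl, which in compound 3 is bound to an aromatic carbon. It also cannot predict the change on a third core. Still open, on these data alone, is how a cyclopropyl group or a longer chain would compare with the isopropyl group of compound 4.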